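Replacing Methoxycarbonyl on the Shared Core

This account rests on a few compounds, and the source may have more. Where it says the series, first, only, none or still open, it means among the compounds named here.

Values measured in a functional assay on A549 cells (Homo sapiens) for cytotoxicity, read by sulforhodamine B assay, with a stated time of 72 h (on this read-out higher numbers stand for weaker inhibition and lower numbers for stronger inhibition), are as follows
Compound 1 `Nc1sc(-c2ccccc2)c(-c2ccc(Cl)cc2)c1C(=O)NC1CC1` gives 4300 nM
Compound 2 `COC(=O)c1c(N)sc(-c2ccc(Cl)cc2)c1-c1ccc(Cl)cc1` gives 5040 nM
Compound 3 `Nc1sc(-c2ccc(F)cc2)c(-c2ccc(Cl)cc2)c1C(=O)N1CCCC1` gives 18800 nM

Among these three, compound 2 at 5040 nM lies within the usual scatter of compound 1 at 4300 nM, so the two cannot be told apart in this assay. Compound 3 at 18800 nM gives a higher number than compound 2, and that gap lies beyond the scatter, which means weaker inhibition for compound 3.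

The next compound to be tested is compound 4 `CC(C)(C)NC(=S)c1c(N)sc(-c2ccc(Cl)cc2)c1-c1ccc(Cl)cc1`. It keeps the core of compound 2 but changes one group: a group of 7 heavy atoms (5 carbon, 1 nitrogen, 1 sulfur; no ring) in place of a group of 4 heavy atoms (2 carbon, 2 oxygen; no ring), on an aromatic carbon. Methoxycarbonyl leaves an aromatic carbon of a five-membered aromatic ring with 1 sulfur, and a larger group with no ring enters there.

Going by the values given here, no two measured compounds differ in one place only, so the data hold no direct precedent for this change. Among the compounds with values here, the only guide is the narrow spread of the three values, which all fall in the micromolar range. On that basis, the expected change is a 1.3-fold higher number from compound 2 to compound 4 (0.11 log units; within the scatter), a step not expected to clear the scatter. For compound 4 the estimated value is 6500 nM, with an expected range of 2000 nM to 20000 nM.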

Compound 4, half-maximal inhibitory concentration: > 50000 nM
Compound 4: only a limit was reported; the forecaster's own chance of this, stated with the estimate: 8%; at least 7.6-fold (0.88 log units) between middle value and limit.
By their numbers in this assay, from the lowest: compounds 1 and 2 (each within the scatter of the next); then compound 3. At a limit, above all of these: compound 4.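

In this assay compound 4 gives > 50000 nM as a limit of the assay and not as a number. The exchange of methoxycarbonyl for this larger group with no ring, on an aromatic carbon of a five-membered aromatic ring with 1 sulfur, is the only change in one place among the compounds shown, and it amounts to an at least 9.9-fold higher number from compound 2 to compound 4 (0.99 log units; beyond the scatter) with the rest of the structure held fixed. As far as these compounds go, this position therefore does not accept every replacement in this assay, something the three earlier values could not show without a comparison in one place, and the size of the step stays open on its upper side: the limit of > 50000 nM in this assay, at which 1 of the 4 values shown sits.

Going by these compounds alone, the single step changes the whole group at once, so it cannot separate the effect of sulfur in place of oxygen from that of the added carbon atoms and the nitrogen. From the compounds shown here alone, how a carboxylic acid, a short alkyl chain or the same group with oxygen in place of its sulfur would read on this aromatic carbon in this assay stays open.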